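Side-chain ends on a shared core in PANC-1 cells

The source may hold more compounds than are shown below. What is called first, only, known or untested is meant among the compounds shown, and "the series" means these compounds.

Compound 1 `CCOc1cc(=O)n(CCCO)c2c1CC(C/C=C(\C)CCC=C(C)C)C(C)(C)C2`: 5800 nM
Compound 2 `CC(C)=CCC/C(C)=C/CC1Cc2c(OCCCNC(=O)c3ccco3)cc(=O)n(CCCO)c2CC1(C)C`: 5200 nM
Compound 3 `CC(C)=CCC/C(C)=C/CC1Cc2c(OCCCNC(=O)c3cccs3)cc(=O)n(CCCO)c2CC1(C)C`: 4900 nM

In a functional assay on PANC-1 cells (Homo sapiens) for inhibition, read by MTT assay, with a stated time of 24 h (on this read-out lower numbers stand for stronger inhibition and higher numbers for weaker inhibition), compound 3 sits level with the other two measured compounds, within the scatter of each. The steps that reach it are a 1.2-fold lower number from compound 1 to compound 3 (0.07 log units; within the scatter) and a 1.1-fold lower number from compound 2 to compound 3 (0.03 log units; within the scatter). The remaining step, a 1.1-fold lower number from compound 1 to compound 2 (0.05 log units; within the scatter), is just as small.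

The next compound is compound 4 `CC(C)=CCC/C(C)=C/CC1Cc2c(OCCCOc3ccc([N+](=O)[O-])cc3)cc(=O)n(CCCO)c2CC1(C)C`, and its difference from compound 3 is 4-nitrophenoxy in place of ((thiophen-2-yl)carbonyl)amino on a saturated chain carbon, three bonds along the chain from an oxygen on an aromatic ring. In words, it carries 4-nitrophenoxy in place of ((thiophen-2-yl)carbonyl)amino on a saturated chain carbon, three bonds along the chain from an oxygen on an aromatic ring.

The measured steps bear on this change only indirectly. They show that building out this chain, and exchanging furan-2-yl for thiophen-2-yl, left the read-out within the scatter across these three compounds. None of them introduces 4-nitrophenoxy, so the data offer no direction for the change, and the range must stay wide. The expected result is a 1.1-fold lower number from compound 3 to compound 4 (0.04 log units; within the scatter), with no shift beyond the scatter anticipated. For compound 4 the estimated value is 4500 nM, with an expected range from 1800 nM to 10000 nM.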

Compound 4, half-maximal inhibitory concentration: 6300 nM
Beside the measured number, compound 4's estimate is 1.4-fold (0.15 log units) below it, and the stated range covers the measured number.
By their numbers in this assay, from the lowest: compounds 3, 2, 1 and 4 (each within the scatter of the next).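

In this assay, 4-nitrophenoxy in place of ((thiophen-2-yl)carbonyl)amino gives a 1.3-fold higher number from compound 3 to compound 4 (0.11 log units; within the scatter) and in place of ((furan-2-yl)carbonyl)amino gives a 1.2-fold higher number from compound 2 to compound 4 (0.08 log units; within the scatter) on this saturated chain carbon, three bonds along the chain from an oxygen on an aromatic ring. The earlier compounds shown here had only tested amide ends with a five-membered aromatic ring and a hydrogen-bond donor, whereas this end has a six-membered aromatic ring of carbon only and no hydrogen-bond donor, and the read-out still stays within the scatter. Measured against the shorter ether, (4-nitrophenoxy)methyl in place of hydrogen gives a 1.1-fold higher number from compound 1 to compound 4 (0.04 log units; within the scatter) and so also stays within the scatter, though nothing available explains why these different chain ends read alike.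

On these data alone, whether a carboxylic acid or a dimethylamino group at the end of this chain, or a longer chain carrying the same ends, would also read level remains open. The compounds shown also cannot separate the nitro group from the phenoxy ring, a question that would need a plain phenoxy end.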